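A Phenoxy Group on the Benzyl Arm of Compound 2

The source may report more compounds than this note shows. Statements on the series, on what has been measured and on what is new or still open speak of the compounds shown alone.

For the measured compounds named here, compound 2 `C(=N/OCc1ccccc1)\c1c(-c2ccc3ccccc3c2)nc2occn12` gives 840 nM in an assay on HepG2 cells for agonist activity at nuclear receptor subfamily 1 group I member 3 (Homo sapiens), read by a luciferase reporter, with a stated time of 23 h (a higher number here means that more compound is needed for the effect, a lower number that less compound is needed), the lowest of the two numbers so far. Going by the values given here, its only measured neighbour is compound 1 `CC(C)(C)c1ccc(CO/N=C/c2c(-c3ccc4ccccc4c3)nc3occn23)cc1`, which in this assay gives 7900 nM; the step of a 9.4-fold lower number from compound 1 to compound 2 (0.97 log units; beyond the scatter) shows that removing the tert-butyl group brought the number down. Compound 3 `C(=N/OCc1ccc(Oc2ccccc2)cc1)\c1c(-c2ccc3ccccc3c2)nc2occn12` differs from compound 2 by phenoxy in place of hydrogen on an aromatic carbon. Among the compounds with values here, the one measured step that bears on this change is a 9.4-fold lower number from compound 1 to compound 2 (0.97 log units; beyond the scatter), where a large group at the same place was accompanied by a much higher number; read in reverse, it suggests that adding another large group there is likely to raise the number again, though phenoxy is not tert-butyl and the size need not match. The account therefore expects a moderate rise, a 3.0-fold higher number from compound 2 to compound 3 (0.47 log units; beyond the scatter). Compound 3 is estimated at 2500 nM in this assay, within 800 nM to 8000 nM.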

Compound 3, half-maximal effective concentration: "not active" (no number reported)
No number was reported for compound 3; there is nothing to compare the estimate with.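

For the compounds shown here, compound 3 is recorded as "not active" in this assay with no number reported, so no step from compound 2 to compound 3 can be read. Nothing shown here accounts for this result. The compounds shown leave open how phenoxy at this place shifts the number, if it gives one at all.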